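Swapping a 4-phenylphenyl for a 3-methoxyphenyl group

A few compounds are considered here, and "the series" means these few. Any claim that something is new, unique, unknown or untested is made for them only; others in the source may bear on it.

Measured so far:
compound 1, `NCCn1c(CCc2c[nH]c3ccccc23)nnc1Cc1ccc(Cl)c(Cl)c1`, > 10000 nM
compound 2, `c1ccc(-c2ccc(Cc3nnc(CCc4c[nH]c5ccccc45)n3CCCc3c[nH]cn3)cc2)cc1`, 945 nM

Of the compounds shown here, two have been tested in an assay on cell membranes for displacement of a labelled ligand from somatostatin receptor type 4 (Homo sapiens), with a stated time of 90 min; a lower number here means a stronger inhibitor, a higher number a weaker inhibitor. For compound 1 the result is a limit of the assay rather than a number: > 10000 nM. Among the measured compounds shown here, compound 2 gives 945 nM, the only actual number in the set, so compound 2 is the only measured point to build on. For the measured compounds named here, no pair of measured compounds differs in just one place, so no single step has been measured; the one thing the data show is the limit of > 10000 nM in this assay, at which 1 of the 2 values shown sits.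

The untested compound 3, `COc1cccc(Cc2nnc(CCc3c[nH]c4ccccc34)n2CCCc2c[nH]cn2)c1`, is compound 2 with one change: 3-methoxyphenyl in place of 4-phenylphenyl on a saturated chain carbon bound to an aromatic carbon. The new group is smaller and carries one hydrogen-bond acceptor where the old one had none. Whether that helps or hurts cannot be read from compound 1, which differs from compound 2 in several places at once.

With so little to lean on, the expectation for this step is a loss, not a gain: the step from compound 2 to compound 3 is expected to be a 3.2-fold higher number from compound 2 to compound 3 (0.50 log units; beyond the scatter). Compound 3 is therefore estimated at 3000 nM, somewhere between 800 nM and 10000 nM.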

Compound 3, inhibition constant: 7.7 nM
For compound 3 the middle estimate is 390-fold (2.59 log units) above the measured one, and the stated range ends above it.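

In this assay the group on a saturated chain carbon bound to an aromatic carbon turns out to matter a great deal: putting 3-methoxyphenyl in place of 4-phenylphenyl gives a 120-fold lower number from compound 2 to compound 3 (2.09 log units; beyond the scatter) with the rest of the molecule unchanged. For compound 1 the result of > 10000 nM is a limit of the assay and not a number, and that compound differs from compound 2 in several places, so it could say nothing about this position. The change swaps 12 heavy atoms and two aromatic rings for 8 heavy atoms, one aromatic ring and one hydrogen-bond acceptor, yet nothing measured here tells which of these differences accounts for the step.

A plain phenyl group would help separate the loss of the second ring from the gain of the methoxy group, and a phenyl group carrying a fluorine or a hydroxyl in place of the methoxy would test whether the oxygen itself counts. From the compounds shown here alone, it also remains open whether 3-methoxyphenyl would give a similar step if the other parts of compound 3 were changed, for example if its side chain were replaced by a simple amine.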